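The source may hold more compounds than are shown below. What is called first, only, known or untested is meant among the compounds shown, and "the series" means these compounds.

Compound 1 `Cc1ccc(-c2ccc(Cl)c(C(=O)NCC3(O)CCCCCC3)c2)nn1`: in a functional assay on HEK293 cells for antagonist activity at P2X purinoceptor 7 (Homo sapiens) (a lower number here means a stronger inhibitor, a higher number a weaker inhibitor), compound 1 gives 18 nM.
Compound 2 `O=C(NCC1(O)CCCCCC1F)c1cc(-c2ncc(F)cn2)ccc1Cl`: in this assay compound 2 gives 17 nM.
Compound 3 `O=C(NCC1(O)CCCCCC1)c1cc(-c2ccc(CO)cn2)ccc1Cl`: in this assay compound 3 gives 17 nM.

Compound 3 stands level with compound 2 at the digits shown, and compound 1 lies within the scatter of it. Compound 4 `O=C(NCC1(O)CCCCCC1)c1cc(-c2ncc(F)cn2)ccc1Cl` differs from compound 3 in one place: 5-fluoropyrimidin-2-yl in place of 5-(hydroxymethyl)pyridin-2-yl on an aromatic carbon. Within the data shown here, the single measured step at this same position, a 1.1-fold lower number from compound 1 to compound 3 (0.02 log units; within the scatter), moved the number by no more than the scatter. Compound 2, which also carries the 5-fluoropyrimidin-2-yl group, gives a number level with compound 3. On that basis no step beyond the scatter is expected in this assay, so that no change at the digits printed from compound 3 to compound 4 (within the scatter) is the expected change. Compound 4 is therefore estimated at 17 nM, within 8 nM to 36 nM.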

Compound 4, half-maximal inhibitory concentration: 16 nM
Beside the measured number, compound 4's estimate is 1.1-fold (0.03 log units) above it; the measured number falls inside the stated range.
By their numbers in this assay, from the lowest: compounds 4, 2, 3 and 1 (each within the scatter of the next).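

In this assay, 5-fluoropyrimidin-2-yl in place of 5-(hydroxymethyl)pyridin-2-yl gives a 1.1-fold lower number from compound 3 to compound 4 (0.03 log units; within the scatter), so the number holds at this position without the hydrogen-bond donor of the group that leaves. The same group in place of 6-methylpyridazin-3-yl gives a 1.1-fold lower number from compound 1 to compound 4 (0.05 log units; within the scatter), while hydrogen in place of fluoro on the saturated ring gives a 1.1-fold lower number from compound 2 to compound 4 (0.03 log units; within the scatter), showing that a change away from this position also stays within the scatter. No measurement at hand explains this flatness. Every group shown at this position is a six-membered aromatic ring. From the compounds shown here alone, whether a carboxylic acid or an open-chain amine there would keep the number stays open.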